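Working notes: methoxy-for-hydrogen steps in an antiproliferative series

The source may report more compounds than this note shows. Statements on the series, on what has been measured and on what is new or still open speak of the compounds shown alone.

Measured compounds:
compound 1, `COc1ccc(C(=O)/C=C\Nc2ccc(-c3nc4cc(OC)c(OC)c(OC)c4s3)cc2C)cc1F`: 1690 nM
compound 2, `COc1ccc2nc(-c3ccc(N/C=C\C(=O)c4ccc(OC)c([N+](=O)[O-])c4)cc3)sc2c1`: 13600 nM
compound 3, `COc1cc(OC)c2sc(-c3ccc(N/C=C\C(=O)c4ccc(OC)c(F)c4)c(C)c3)nc2c1`: 15300 nM

In a functional assay on A549 cells (Homo sapiens) for antiproliferative activity, read by sulforhodamine B assay, with a stated time of 48 h (a higher number here means a weaker inhibitor, a lower number a stronger inhibitor), compound 1 gives 1690 nM, compound 2 gives 13600 nM and compound 3 gives 15300 nM. Compound 2 and compound 3 differ in more than one place; the difference between their cores is not broken down here, and their two values lie within the scatter of each other.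

From compound 3 to compound 1 the change is methoxy in place of hydrogen on an aromatic carbon, and it gave a 9.1-fold lower number from compound 3 to compound 1 (0.96 log units; beyond the scatter).

Compound 4, `COc1ccc2nc(-c3ccc(N/C=C\C(=O)c4cc(OC)c(OC)c([N+](=O)[O-])c4)cc3)sc2c1`, is not yet measured in this assay; it stands to compound 2 as methoxy in place of hydrogen on an aromatic carbon. This is the same kind of change, not the same: in compound 1 the entering group sits on a ring that is part of a fused or bridged system of two rings, ortho to two methoxy groups, meta to a fused ring and para to a fused ring; in compound 4 it sits ortho to one methoxy group, meta to a large group and meta to a nitro group.

For compound 4 in this assay a step near a 4.5-fold lower number from compound 2 to compound 4 (0.66 log units; beyond the scatter) is expected. Within the data shown here, this rests on the single earlier step of a 9.1-fold lower number from compound 3 to compound 1 (0.96 log units; beyond the scatter) and on compound 2 at 13600 nM; with only one precedent, on a differently placed carbon, the size is uncertain. Compound 4 is estimated at 3000 nM, within 1000 nM to 9000 nM.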

Compound 4, half-maximal inhibitory concentration: 21600 nM
Compound 4: middle estimate off by 7.2-fold (0.86 log units), on the low side; measured number outside the range, above it.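

In this assay the new step is a 1.6-fold higher number from compound 2 to compound 4 (0.20 log units; within the scatter), so methoxy in place of hydrogen on an aromatic carbon leaves no change beyond the scatter on this core. The size of the step did not carry from one core to the other: the same change on two cores in this assay, a 9.1-fold lower number (0.96 log units; beyond the scatter) from compound 3 to compound 1 and a 1.6-fold higher number (0.20 log units; within the scatter) from compound 2 to compound 4, 14-fold (1.16 log units) apart, beyond the scatter of two such steps

Two pairs do not show whether the place of the entering group or the rest of the core sets this gap: in compound 4 it sits ortho to one methoxy group, meta to a large group and meta to a nitro group, on a different ring from that in compound 1.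

Open, as far as these compounds go, is how the step on compound 4 would read with an amine or a carboxylic acid in place of the nitro group. Also open, from the compounds shown here alone, is whether a longer chain, such as ethoxy, would read like the entering methoxy.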